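Para-bromo on the phenyl of a weak tracheal inhibitor

The compounds below may be only part of what the source reports. "The series", "measured", "known", "first", "only" and "open" are said of these compounds alone.

Measured compounds:
compound 1 `CO[C@@]12CCN(C)C[C@H]1[C@H](c1ccccc1)C(C#N)=C(N)O2`, 19800 nM
compound 2 `CCN1CC[C@@]2(OC)OC(N)=C(C#N)[C@@H](c3ccccc3)[C@@H]2C1`, 23400 nM

Of the compounds shown here, two have been measured in a functional assay on trachea (Cavia porcellus); a lower number here means a stronger inhibitor, a higher number a weaker inhibitor. Among the compounds with values here, compound 1 `CO[C@@]12CCN(C)C[C@H]1[C@H](c1ccccc1)C(C#N)=C(N)O2` gives 19800 nM, and compound 2 `CCN1CC[C@@]2(OC)OC(N)=C(C#N)[C@@H](c3ccccc3)[C@@H]2C1` gives 23400 nM; the single step between them, a 1.2-fold higher number from compound 1 to compound 2 (0.07 log units; within the scatter), is within the scatter, so compound 1 stands at a number that cannot be told apart from that of compound 2 in this assay. Compound 3 `CO[C@@]12CCN(C)C[C@H]1[C@H](c1ccc(Br)cc1)C(C#N)=C(N)O2` has not yet been measured. It differs from compound 1 by bromo in place of hydrogen on an aromatic carbon, which amounts to phenyl becoming 4-bromophenyl.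

Within the data shown here, no measured step touches the aromatic ring: the one known step concerns only the amine nitrogen in the ring, and it was within the scatter. There is thus no measured basis for a step in either direction in this assay, and the expectation is a number close to that of compound 1, with a wide range. Compound 3 is therefore estimated at 15000 nM, between 5000 nM and 45000 nM, which corresponds to an expected step of a 1.3-fold lower number from compound 1 to compound 3 (0.12 log units; within the scatter).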

Compound 3, half-maximal inhibitory concentration: 7900 nM
Beside the measured number, compound 3's estimate is 1.9-fold (0.28 log units) above it; measured number inside the range.
By their numbers in this assay, from the lowest: compound 3; then compounds 1 and 2 (each within the scatter of the next).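

In this assay, within the data shown here, the aromatic ring proves to be a place where a single change can be read: the new step is a 2.5-fold lower number from compound 1 to compound 3 (0.40 log units; beyond the scatter), whereas the only earlier step, a 1.2-fold higher number from compound 1 to compound 2 (0.07 log units; within the scatter), concerned a saturated chain carbon bound to the amine nitrogen and did not separate its two compounds. One bromo on an aromatic carbon, para to a large group, is therefore enough to move the number beyond the scatter, although the step is modest and compound 3 still gives 7900 nM in this assay. Nothing available bears on the reason for this step.

On these data alone, how a chloro, methyl or methoxy group would compare at this same place, and how bromo would fare on another carbon of the aromatic ring, remains open. Also open, as far as these compounds go, are whether the bromo step carries over to the core of compound 2, and how a larger group on the amine nitrogen, such as benzyl, would read in this assay.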